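The compounds below may be only part of what the source reports. "The series", "measured", "known", "first", "only" and "open" are said of these compounds alone.

Measured so far in an ADME assay on Caco-2 cells (Homo sapiens) for permeability, in the apical to basolateral direction; on this read-out higher numbers stand for higher permeability and lower numbers for lower permeability:

- compound 1 `Cn1cncc1CN1CC(N(CC2CCN(C(=O)CNC(=O)OC(C)(C)C)CC2)S(=O)(=O)c2ccccn2)Cc2cc(C#N)ccc21`: 0.5 10^-6 cm/s
- compound 2 `Cn1cncc1CN1CC(N(CC2CCN(C(=O)Nc3ccc(Br)cc3)CC2)S(=O)(=O)c2ccccn2)Cc2cc(C#N)ccc21`: 0.6 10^-6 cm/s
- compound 3 `Cn1cncc1CN1CC(N(CC2CCN(C(=O)CC(C)(C)C)CC2)S(=O)(=O)c2ccccn2)Cc2cc(C#N)ccc21`: 0.5 10^-6 cm/s

Compound 1 stands level with compound 3 at the digits shown, and the two together hold the lowest numbers of the three. The step of a 1.2-fold higher number from compound 1 to compound 2 (0.08 log units; within the scatter) stays within the scatter, so none of the three is separated from the others.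

Compound 4 `Cn1cncc1CN1CC(N(CC2CCN(C(=O)C3CC3)CC2)S(=O)(=O)c2ccccn2)Cc2cc(C#N)ccc21` differs from compound 1 by cyclopropyl in place of ((tert-butoxycarbonyl)amino)methyl on a carbonyl carbon. Going by the values given here, two measured steps bear on this position on the carbonyl carbon: no change at the digits printed from compound 1 to compound 3 (within the scatter) also removes the (tert-butoxycarbonyl)amino group and leaves the number unchanged, and a 1.2-fold lower number from compound 2 to compound 3 (0.08 log units; within the scatter) shows that a second, quite different replacement there moves the number only within the scatter. On this basis the step of a 1.2-fold higher number from compound 1 to compound 4 (0.08 log units; within the scatter) is expected to stay within the scatter, with no direction assigned. For compound 4 the value in this assay is therefore estimated at 0.6 10^-6 cm/s, expected to fall between 0.3 10^-6 cm/s and 1.2 10^-6 cm/s.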

Compound 4, apparent permeability: 0.5 10^-6 cm/s
For compound 4 the middle estimate is 1.2-fold (0.08 log units) above the measured one, within the range that was stated.
By their numbers in this assay, from the lowest: compounds 1, 3, 4 and 2 (each within the scatter of the next).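

In this assay, cyclopropyl brings a three-membered ring of carbon only onto the carbonyl carbon, and it separates from none of the earlier groups: no change at the digits printed from compound 1 to compound 4 (within the scatter), no change at the digits printed from compound 3 to compound 4 (within the scatter) and a 1.2-fold lower number from compound 2 to compound 4 (0.08 log units; within the scatter). Going from 9 heavy atoms in ((tert-butoxycarbonyl)amino)methyl to 3 in cyclopropyl, with the hydrogen-bond donor and acceptors of the leaving group gone, also stays within the scatter, so four different groups at this position now remain unseparated. No measurement shown here accounts for this absence of separation.

Going by these compounds, whether a carboxylic acid or an amine on the carbonyl carbon would move the number in this assay beyond the scatter remains open. On these data alone, all four compounds share the core of compound 1, so changes elsewhere in the structure also remain untested here.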